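Ethynyl for phenyl on two cores, cell growth notes

A few compounds are considered here, and "the series" means these few. Any claim that something is new, unique, unknown or untested is made for them only; others in the source may bear on it.

Compound 1 `Cc1nc(N)c2c(-c3ccccc3)cn([C@@H]3O[C@H](CO)[C@@H](O)[C@H]3O)c2n1` and compound 2 `C#Cc1cn([C@@H]2O[C@H](CO)[C@@H](O)[C@H]2O)c2nc(C)nc(N)c12` share one core; compound 3 `COc1ncnc2c1c(-c1ccccc1)cn2[C@@H]1O[C@H](CO)[C@@H](O)[C@H]1O` and compound 4 `C#Cc1cn([C@@H]2O[C@H](CO)[C@@H](O)[C@H]2O)c2ncnc(OC)c12` share another, and the difference between the two cores is not broken down here. In an ADME assay on BJ cells (Homo sapiens), read by MTT assay, with a stated time of 72 h (on this read-out higher numbers stand for weaker inhibition and lower numbers for stronger inhibition), compound 1 gives > 100000 nM, which is a limit of the assay. In this assay compound 2 gives > 100000 nM, also a limit. In this assay compound 3 gives > 100000 nM, again a limit. The change from compound 1 to compound 2 is ethynyl in place of phenyl on an aromatic carbon and its step is a step that the two limits leave unreadable from compound 1 to compound 2; it cannot be sized because of the limit of > 100000 nM in this assay, at which 3 of the 3 values shown sit. The same change, (ethynyl in place of phenyl on an aromatic carbon), carries compound 3 to compound 4. Compound 4 is expected to remain at the limit, so the step that the limit leaves unreadable from compound 3 to compound 4 is estimated as flat. Compound 4 is estimated at 200000 nM, from 60000 nM to 600000 nM.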

Compound 4, half-maximal inhibitory concentration: 98400 nM
The estimate for compound 4 lay 2.0-fold (0.31 log units) above the measured number, and the stated range covers the measured number.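

In this assay the change of phenyl to ethynyl gives an at least 1.0-fold lower number from compound 3 to compound 4 (0.00 log units; that floor lies within the scatter), so the size of the step on this core is not established, and compound 4 reads 98400 nM. Compound 3 gives > 100000 nM, which is a limit and not a number. The step on the core of compound 1 cannot be read, so whether the change behaves alike on the two cores stays unsettled: the limit of > 100000 nM in this assay, at which 3 of the 4 values shown sit.

Open, on these data alone, is how an amine, a carboxylic acid or a longer chain in place of ethynyl at this aromatic carbon would read in this assay. Also open is how the two cores compare on their own, since every pair shown changes only phenyl to ethynyl.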